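This account rests on a few compounds, and the source may have more. Where it says the series, first, only, none or still open, it means among the compounds named here.

Compound 1 `O=C(O)c1cc2ccc(Cn3ccnc3)cc2s1` gives 18 nM in an assay for inhibition of Thromboxane-A synthase (Homo sapiens); a lower number here means a stronger inhibitor, a higher number a weaker inhibitor.
Compound 2 `O=C(O)c1cc2ccc(Cn3ccnc3)cc2[nH]1` gives 33 nM in this assay.
Compound 3 `Cc1c(C(=O)O)sc2cc(Cn3ccnc3)ccc12` gives 5.2 nM in this assay.

Among these three numbers compound 1 stands second highest: compound 2 is within the scatter of it, while compound 3 lies beyond the scatter, with a 3.5-fold lower number from compound 1 to compound 3 (0.54 log units; beyond the scatter). Compound 4 `O=C(O)c1cc2c(O)cc(Cn3ccnc3)cc2s1` has not yet been measured in this assay. It differs from compound 1 in one place: hydroxy in place of hydrogen on an aromatic carbon.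

Among the measured compounds shown here, only one measured step touches a substituent on the shared core, and that step, a 3.5-fold lower number from compound 1 to compound 3 (0.54 log units; beyond the scatter), concerns a methyl group at a different position, not a hydroxy group; the data hold no hydroxy analogue at all. That step therefore gives only a weak hint that a small group on the core can be tolerated. No direct guide exists for the present change, so a step of no more than modest size is expected, in either direction.

For compound 4 the estimate is 22 nM, with a range from 7 nM to 70 nM, which would mean an expected step of a 1.2-fold higher number from compound 1 to compound 4 (0.09 log units; within the scatter).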

Compound 4, half-maximal inhibitory concentration: 52 nM
Beside the measured number, compound 4's estimate is 2.4-fold (0.37 log units) below it, within the range that was stated.
By their numbers in this assay, from the lowest: compound 3; then compounds 1, 2 and 4 (each within the scatter of the next, the first and the last beyond it).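

Among the compounds shown here, on the shared core, hydroxy in place of hydrogen on this aromatic carbon, ortho to a fused ring and meta to the (1H-imidazol-1-yl)methyl group, is the first hydroxy change seen, and in this assay it gives a 2.9-fold higher number from compound 1 to compound 4 (0.46 log units; beyond the scatter) as its step. The earlier methyl change, with a 3.5-fold lower number from compound 1 to compound 3 (0.54 log units; beyond the scatter) at a different position, runs the opposite way, so a small group on the core does not move the number in one fixed direction, although the two steps differ in both group and place. Nothing available accounts for the direction or size of the step on adding hydroxy.

Going by these compounds, whether a methoxy group, a fluorine atom or an amine at this carbon would give a similar step remains open. On these data alone, it is also open whether hydroxy would give a similar step at another carbon of the core, or on the methyl-bearing core of compound 3.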